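A few compounds are considered here, and "the series" means these few. Any claim that something is new, unique, unknown or untested is made for them only; others in the source may bear on it.

Measured compounds:
- compound 1 `COc1ccc2c(=O)c(/C=C/C(=O)Nc3ccccc3Cl)coc2c1` gives 1010000 nM in an ADME assay on HepG2 2.2.15 cells (Homo sapiens) for cytotoxicity, read by MTT assay, with stated times of 48 h and 9 days; a lower number here means that less compound is tolerated, a higher number that more compound is tolerated
- compound 2 `COc1ccc2c(=O)c(/C=C/C(=O)NCc3cccc(F)c3)coc2c1` gives 475000 nM in this assay
- compound 3 `COc1ccc2c(=O)c(/C=C/C(=O)NCc3ccc(C)cc3)coc2c1` gives 257000 nM in this assay

Of the three, compound 3 stands at the lowest number. Its step from compound 2 is within the scatter, so no order between compound 2 and compound 3 can be read, while the step of a 3.9-fold lower number from compound 1 to compound 3 (0.59 log units; beyond the scatter) is beyond it, and only toward compound 1 does compound 3 clearly differ.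

Compound 4 `COc1ccc2c(=O)c(/C=C/C(=O)Nc3ccccc3C)coc2c1` is not yet measured. Against compound 3 it shows (2-methylphenyl in place of 4-methylbenzyl on an amide-type nitrogen). This change takes the nitrogen substituent back from a benzyl type to a phenyl type, the arrangement seen in compound 1. Within the data shown here, the steps that bear on it are a 2.1-fold lower number from compound 1 to compound 2 (0.33 log units; beyond the scatter) and a 3.9-fold lower number from compound 1 to compound 3 (0.59 log units; beyond the scatter), both modest and both moving to a lower number when a benzyl group replaced the 2-chlorophenyl group. The present change runs the other way, and a step in the opposite direction of comparable size is therefore expected, an upward move in this assay for compound 4. The step of a 1.8-fold lower number from compound 2 to compound 3 (0.27 log units; within the scatter) is within the scatter and adds nothing to the direction.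

Compound 4 is accordingly estimated at 800000 nM, between 350000 nM and 1600000 nM, which corresponds to an expected step of a 3.1-fold higher number from compound 3 to compound 4 (0.49 log units; beyond the scatter).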

Compound 4, half-maximal cytotoxic concentration: 59700 nM
Compound 4: middle estimate off by 13-fold (1.13 log units), on the high side; measured number outside the range, below it.
By their numbers in this assay, from the lowest: compound 4; then compounds 3 and 2 (each within the scatter of the next); then compound 1.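

In this assay a phenyl type on the amide-type nitrogen does not by itself give a higher number, as the 2-methylphenyl group of compound 4 shows with a 4.3-fold lower number from compound 3 to compound 4 (0.63 log units; beyond the scatter) and with an 8.0-fold lower number from compound 2 to compound 4 (0.90 log units; beyond the scatter) against the two benzyl types. Compound 1 had been the only phenyl type, so its place above compounds 2 and 3 could have been read as a difference between phenyl and benzyl, and compound 4, now the lowest of the four, goes against that reading. The substituent on the aromatic ring counts for more here than the earlier steps suggested, since methyl in place of chloro on an aromatic carbon gives a 17-fold lower number from compound 1 to compound 4 (1.23 log units; beyond the scatter) as the largest step in the set, yet no measured property or other finding accounts for this difference.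

On these data alone, it remains open whether the unsubstituted phenyl group would stand nearer compound 1 or compound 4, and whether a 2-methoxyphenyl or 2-aminophenyl group would follow the chloro or the methyl compound. Also open, as far as these compounds go, is whether a 2-methylbenzyl or 2-chlorobenzyl group would repeat the same gap between methyl and chloro on the benzyl type.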